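Swapping a Methoxy for a Methyl on the Ketone Ring

The compounds below may be only part of what the source reports. "The series", "measured", "known", "first", "only" and "open" are said of these compounds alone.

Of the compounds shown here, two built on the same core have so far been tested in a functional assay on A549 cells (Homo sapiens) for antiproliferative activity, read by MTT assay, with a stated time of 24 h; on this read-out higher numbers stand for weaker inhibition and lower numbers for stronger inhibition. Compound 1 `COc1ccc(C(=O)/C=C/c2cc(-c3cc(OC)c(OC)c(OC)c3)n3nc(-c4ccccc4)cc3n2)cc1` carries a methoxy group on the phenyl ring attached to the carbonyl, and in this assay compound 1 gives 14600 nM. Compound 2 `COc1ccc(-c2cc(/C=C/C(=O)c3ccc(OC)c(OC)c3)nc3cc(-c4ccccc4)nn23)cc1` gives 7400 nM in this assay. Of the two numbers, that of compound 1 is the higher one, but the two values lie within the usual scatter of repeated measurements, so nothing separates them.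

Compound 3 `COc1cc(-c2cc(/C=C/C(=O)c3ccc(C)cc3)nc3cc(-c4ccccc4)nn23)cc(OC)c1OC` is the next compound to be tested. Compared with compound 1, the change is methyl in place of methoxy on an aromatic carbon. Going by the values given here, no measured pair in this set shows what such a change does on its own, so there is no direct guide.

The step from compound 1 to compound 3 is expected to be small, a 1.2-fold lower number from compound 1 to compound 3 (0.09 log units; within the scatter), not clearly beyond the scatter in either direction. Compound 3 is therefore estimated to give about 12000 nM in this assay, with a range from 5000 nM to 30000 nM.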

Compound 3, half-maximal inhibitory concentration: 19400 nM
Estimate against measurement, compound 3: 1.6-fold (0.21 log units) below; measured number inside the range.
By their numbers in this assay, from the lowest: compounds 2, 1 and 3 (each within the scatter of the next, the first and the last beyond it).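

Going by these compounds alone, this is the first measured pair for this swap on the ring attached to the carbonyl, and in this assay the step reads a 1.3-fold higher number from compound 1 to compound 3 (0.12 log units; within the scatter), so at this place on the shared core, methyl and methoxy cannot be told apart. The swap removes an oxygen and the one hydrogen-bond acceptor counted for the methoxy group, yet the result stays within the usual scatter, so this assay gives no sign that the oxygen matters here. Nothing measured on these compounds offers an explanation for this result.

The compounds shown leave open whether a group of a different kind at this place, such as an amine, a carboxylic acid or a longer chain, would move the number clearly beyond the scatter from that of compound 1. They also leave open whether the same swap would be as uneventful at the other methoxy groups of compound 1, since this single pair speaks only for the position para to a large group on the ring attached to the carbonyl.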